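Moving a hydroxyl on the pyridine-adjacent phenyl ring

A few compounds are considered here, and "the series" means these few. Any claim that something is new, unique, unknown or untested is made for them only; others in the source may bear on it.

Two triaryl pyridines carrying three phenol rings have been measured. Compound 1 `Oc1ccc(-c2cc(-c3ccccc3O)cc(-c3cccc(O)c3)n2)cc1` gives 650 nM in a functional assay on T47D cells (Homo sapiens) for cytotoxicity, read by CCK-8 assay, with a stated time of 4 days; on this read-out higher numbers stand for weaker inhibition and lower numbers for stronger inhibition. Compound 2 `Oc1cccc(-c2cc(-c3cccc(O)c3)nc(-c3ccccc3O)c2)c1` gives 50000 nM in this assay, the highest of the two numbers and far beyond the scatter from compound 1. Compound 3 `Oc1ccc(-c2cc(-c3cccc(O)c3)cc(-c3cccc(O)c3)n2)cc1` has not yet been measured. It differs from compound 2 in one place: 4-hydroxyphenyl in place of 2-hydroxyphenyl on an aromatic carbon. Going by the values given here, no step between two measured compounds isolates this exact change, so no measured step can be quoted for it. Compound 1, the stronger inhibitor, also carries a 4-hydroxyphenyl next to the ring nitrogen, which makes a move toward lower numbers plausible. Compound 3 is therefore expected to show a step of a 17-fold lower number from compound 2 to compound 3 (1.22 log units; beyond the scatter) and to land near 3000 nM, with a range from 500 nM to 20000 nM.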

Compound 3, half-maximal inhibitory concentration: 3920 nM
Beside the measured number, compound 3's estimate is 1.3-fold (0.12 log units) below it; measured number inside the range.
By their numbers in this assay, from the lowest: compound 1; then compound 3; then compound 2.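

In this assay, the group next to the ring nitrogen proves sensitive to where its hydroxyl sits: 4-hydroxyphenyl in place of 2-hydroxyphenyl gives a 13-fold lower number from compound 2 to compound 3 (1.11 log units; beyond the scatter), although the two groups have the same atoms. The other single change, which replaces a 2-hydroxyphenyl with a 3-hydroxyphenyl, gives a 6.0-fold higher number from compound 1 to compound 3 (0.78 log units; beyond the scatter), so losing a 2-hydroxyphenyl lowers the number in one step and raises it in the other.

Every compound shown carries only hydroxyphenyl groups, so it stays open whether the hydroxyl itself matters or only its position; a methoxy group or an amine in its stead would separate the two. From the compounds shown here alone, whether these steps hold on other cells also stays open. Nothing shown gives a reason for either step.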